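Swapping Cyano for Trifluoromethyl at High Tolerated Concentrations

The source may hold more compounds than are shown below. What is called first, only, known or untested is meant among the compounds shown, and "the series" means these compounds.

Values measured in an ADME assay on BE(2)-C cells (Homo sapiens) for cytotoxicity, read by MTT assay, with a stated time of 20 h; a higher number here means that more compound is tolerated, a lower number that less compound is tolerated:
- compound 1 `O=C(c1cc2ccccc2n1Cc1ccc(Cl)cc1)N1CCC(C(=O)N2CCC[C@H]2CO)CC1`: 98900 nM
- compound 2 `O=C(c1cc2ccccc2n1Cc1ccc(Cl)cc1)N1CCC(C(=O)N2CCOCC2)CC1`: > 100000 nM (a limit, not a number)
- compound 3 `CN(Cc1ccccc1)C(=O)C1CCN(C(=O)c2cc3ccccc3n2Cc2ccc(C#N)cc2)CC1`: > 100000 nM (a limit, not a number)

Compound 3 has no exact value, only the limit > 100000 nM. It shares that limit with one other compound, as the limit of > 100000 nM in this assay, at which 2 of the 3 values shown sit, shows.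

The next compound to be tested is compound 4 `CN(Cc1ccccc1)C(=O)C1CCN(C(=O)c2cc3ccccc3n2Cc2ccc(C(F)(F)F)cc2)CC1`. It carries trifluoromethyl in place of cyano on an aromatic carbon, para to a large group (trifluoromethyl in place of cyano on an aromatic carbon).

Within the data shown here, no measured step makes this exchange. Among the measured compounds shown here, the only step available, a number no lower from compound 1 to compound 2 (the limit leaves the size open), swaps a different group, and its size cannot be read. It therefore gives no guide to the size or direction of the change here.

The best remaining guide is the general level of the measured compounds. For the measured compounds named here, because compound 1 gives 98900 nM as the only exact number, a result for compound 4 in that region is expected.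

The expected change, an at least 1.1-fold lower number from compound 3 to compound 4 (0.04 log units; that floor lies within the scatter), is none beyond the usual scatter in this assay.

For compound 4 the estimate is 90000 nM, with an expected range from 40000 nM to 100000 nM.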

Compound 4, half-maximal cytotoxic concentration: 90300 nM
Beside the measured number, compound 4's estimate is 1.0-fold (0.00 log units) below it, and the stated range covers the measured number.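

Among these compounds, at this position, on an aromatic carbon para to a large group, trifluoromethyl in place of cyano gives the first readable step in this assay: an at least 1.1-fold lower number from compound 3 to compound 4 (0.04 log units; that floor lies within the scatter). Among the compounds shown here, compound 4 gives 90300 nM, an exact number, so this compound can be placed on the scale, and the earlier compounds offered no such reading for this exchange. The step has only a floor, and that floor lies within the scatter, so its true size stays unknown because compound 3 carries a limit and not a number: the limit of > 100000 nM in this assay, at which 2 of the 4 values shown sit.

The compounds shown leave open how other groups on this same aromatic carbon, such as an amine or a carboxylic acid, would read in this measurement. For the compounds shown here, they also leave open whether trifluoromethyl in place of cyano gives a similar step when the rest of the molecule differs, since only one pair of compounds carries this exchange.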